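The source may report more compounds than this note shows. Statements on the series, on what has been measured and on what is new or still open speak of the compounds shown alone.

The measured compounds and their numbers:

Compound 1, `COC(=O)C(Cc1cccc(C(=N)N)c1)C(/C=C/c1ccccc1)NC(=O)c1ccc(-c2ccccc2C)cc1`, gives 3100 nM in an assay on isolated protein (Oryctolagus cuniculus) for inhibition of Trypsin (Homo sapiens); a lower number here means a stronger inhibitor, a higher number a weaker inhibitor.
Compound 2, `COC(=O)C(Cc1cccc(C(=N)N)c1)C(/C=C/c1ccccc1)NC(=O)c1ccc(-c2ccc(C)cc2)cc1`, gives 2800 nM in this assay.
Compound 3, `COC(=O)C(Cc1cccc(C(=N)N)c1)C(/C=C/c1ccccc1)NC(=O)c1ccc(-c2ccccc2OC)cc1`, gives 1800 nM in this assay.

Compound 3 has the lowest of the three numbers, but its steps to the other two, a 1.6-fold lower number from compound 2 to compound 3 (0.19 log units; within the scatter) and a 1.7-fold lower number from compound 1 to compound 3 (0.24 log units; within the scatter), both lie within the scatter, so no order among the three can be claimed. The three compounds share one core and differ only in the group carried on the outer ring of the amide.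

Compound 4, `COC(=O)C(Cc1cccc(C(=N)N)c1)C(/C=C/c1ccccc1)NC(=O)c1ccc(-c2ccc(OC)cc2)cc1`, has not been measured. It differs from compound 3 in one place: 4-methoxyphenyl in place of 2-methoxyphenyl on an aromatic carbon. The closest comparison already measured is the corresponding move of a methyl group, a 1.1-fold lower number from compound 1 to compound 2 (0.04 log units; within the scatter), which stayed within the scatter. The methyl-to-methoxy replacement, a 1.7-fold lower number from compound 1 to compound 3 (0.24 log units; within the scatter), also stayed within the scatter. On this basis the change from compound 3 to compound 4 is expected to give no step beyond the scatter in this assay, that is, an expected step of a 1.1-fold lower number from compound 3 to compound 4 (0.02 log units; within the scatter). The estimated number for compound 4 in this assay is therefore 1700 nM, with a range from 800 nM to 3600 nM.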

Compound 4, half-maximal inhibitory concentration: 2900 nM
For compound 4 the middle estimate is 1.7-fold (0.23 log units) below the measured one, and the stated range covers the measured number.
By their numbers in this assay, from the lowest: compounds 3, 2, 4 and 1 (each within the scatter of the next).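

In this assay, going by these compounds alone, moving the methoxy group on this aromatic carbon gives a 1.6-fold higher number from compound 3 to compound 4 (0.21 log units; within the scatter), so the 2-methoxyphenyl and 4-methoxyphenyl groups cannot be told apart here, and the same held for the two methylphenyl groups in the earlier compounds. The methyl-to-methoxy replacement can now also be read with the group para to a large group, where it gives a 1.0-fold higher number from compound 2 to compound 4 (0.02 log units; within the scatter), and the step that changes both the group and its place, a 1.1-fold lower number from compound 1 to compound 4 (0.03 log units; within the scatter), likewise stays within the scatter. Read on two cores, the replacement gives results that cannot be distinguished: the same change on two cores in this assay, a 1.7-fold lower number (0.24 log units; within the scatter) from compound 1 to compound 3 and a 1.0-fold higher number (0.02 log units; within the scatter) from compound 2 to compound 4, 1.8-fold (0.25 log units) apart, within the scatter of two such steps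

The compounds shown carry only methyl and methoxy on the outer ring, so it remains open whether an amine or a carboxylic acid there would give a step beyond the scatter. All four compounds also share the rest of their structure, which leaves open what a change elsewhere on the shared core would do in this assay.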